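This account rests on a few compounds, and the source may have more. Where it says the series, first, only, none or still open, it means among the compounds named here.

Series in a functional assay on HL-60 cells (Homo sapiens) for antiproliferative activity, with a stated time of 24 h; on this read-out higher numbers stand for weaker inhibition and lower numbers for stronger inhibition:
- compound 1 `NC(=O)c1c(NC(=O)c2ccccc2Cl)sc2c1CCN(Cc1cc(Cl)cc(Cl)c1)C2`: in this assay compound 1 gives 15800 nM
- compound 2 `NC(=O)c1c(NC(=O)c2ccccc2Cl)sc2c1CCN(C(=S)Nc1ccccc1F)C2`: in this assay compound 2 gives 4970 nM
- compound 3 `Cc1ccccc1NC(=S)N1CCc2c(sc(NC(=O)c3ccccc3Cl)c2C(N)=O)C1`: in this assay compound 3 gives 22600 nM

Compound 3 has the highest number of the three. Its nearest neighbour is compound 1, and that gap, a 1.4-fold higher number from compound 1 to compound 3 (0.16 log units; within the scatter), lies within the scatter, so no order between the two can be read. The step to compound 2, a 4.5-fold higher number from compound 2 to compound 3 (0.66 log units; beyond the scatter), is beyond the scatter, with compound 2 at the lower number.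

Compound 4 `NC(=O)c1c(NC(=O)c2ccccc2Cl)sc2c1CCN(C(=O)Nc1c(Cl)cccc1Cl)C2` differs from compound 3 on the amine nitrogen in the ring: a group of 11 heavy atoms (7 carbon, 1 nitrogen, 1 oxygen, 2 chlorine; one six-membered aromatic ring of carbon only) in place of a group of 10 heavy atoms (8 carbon, 1 nitrogen, 1 sulfur; one six-membered aromatic ring of carbon only), on an amine nitrogen in a ring. Within the data shown here, no measured step changes this group in the same way. Among the measured compounds shown here, the only step touching the aryl substituent here is a 4.5-fold higher number from compound 2 to compound 3 (0.66 log units; beyond the scatter), a modest change in which methyl in place of fluoro raised the number. The step of a 3.2-fold lower number from compound 1 to compound 2 (0.50 log units; beyond the scatter) shows the same nitrogen carrying a quite different group and moving modestly. Both carry only loosely onto a halogen-bearing carbamoyl. The expected step is therefore a 2.5-fold lower number from compound 3 to compound 4 (0.40 log units; beyond the scatter), with little confidence in direction. For compound 4 the estimate in this assay is 9000 nM, range 2500 nM to 32000 nM.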

Compound 4, half-maximal inhibitory concentration: 17700 nM
Compound 4: the middle estimate sits 2.0-fold (0.29 log units) below what was measured, within the range that was stated.
By their numbers in this assay, from the lowest: compound 2; then compounds 1, 4 and 3 (each within the scatter of the next).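

In this assay, (2,6-dichlorophenyl)carbamoyl on the amine nitrogen in the ring gives a 1.3-fold lower number from compound 3 to compound 4 (0.11 log units; within the scatter), so exchanging the group of compound 3 for this one shows no readable change at this position. The same holds against the 3,5-dichlorobenzyl group, with a 1.1-fold higher number from compound 1 to compound 4 (0.05 log units; within the scatter), so compounds 1, 3 and 4 stand together without any order despite carrying three different groups on that nitrogen. Compound 2 alone separates from this cluster, with a 3.6-fold higher number from compound 2 to compound 4 (0.55 log units; beyond the scatter) adding a third step beyond the scatter to the two already seen, and it therefore has the lowest number of the four, although the group exchanged in this step differs in more than one feature, so the step cannot be assigned to any one of them.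

No measurement available here explains why compound 2 stands apart. Still open, from the compounds shown here alone, are whether the carbonyl or the thiocarbonyl matters when the aryl group is held constant, and how a carboxylic acid, a morpholine or a longer alkyl chain on the same nitrogen would compare with compound 2.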